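This account rests on a few compounds, and the source may have more. Where it says the series, first, only, none or still open, it means among the compounds named here.

Measured in a functional assay on KB cells (Homo sapiens) for cytotoxicity, read by MTT assay, with a stated time of 72 h; a higher number here means that more compound is needed for the effect, a lower number that less compound is needed:
Compound 1 `CCc1cccc2c(OC)c(-c3occ(C)c3C(=O)OC)ccc12` gives 1.7 ug/mL
Compound 2 `CCCOC(=O)c1c(C)coc1-c1ccc2c(CC)cccc2c1OC` gives > 10 ug/mL, which is a limit of the assay
Compound 3 `CCc1cccc2c(OC)c(-c3occ(C)c3C(=S)OC)ccc12` gives 4.3 ug/mL

Compound 3 has the higher of the two actual numbers in this assay, and compound 1 is its nearest neighbour, with a lower number. Compound 2 is known only as a limit.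

Compound 4 `CCc1cccc2c(OC)c(-c3occ(C)c3COC)ccc12` differs from compound 3 in one place: a group of 3 heavy atoms (2 carbon, 1 oxygen; no ring) in place of a group of 4 heavy atoms (2 carbon, 1 oxygen, 1 sulfur; no ring), on an aromatic carbon. The methoxymethyl group enters on an aromatic carbon of a five-membered aromatic ring with 1 oxygen.

The measured changes at this same place give some idea of its sensitivity. Both steps away from compound 1 raised the number: a 2.5-fold higher number from compound 1 to compound 3 (0.40 log units; beyond the scatter) and an at least 5.8-fold higher number from compound 1 to compound 2 (0.76 log units; beyond the scatter). The remaining step runs the other way: an at least 2.3-fold lower number from compound 2 to compound 3 (0.36 log units; beyond the scatter). None of these steps removes the double bond outside aromatic rings, so they set a rough size but do not fix a direction for the new change. A clear move in either direction is therefore not expected, and the estimated step is a 1.2-fold higher number from compound 3 to compound 4 (0.07 log units; within the scatter), with a modest shift either way still possible. The estimate for compound 4 is 5 ug/mL, with an expected range from 1.5 ug/mL to 14 ug/mL in this assay.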

Compound 4, concentration for half-maximal effect: > 10 ug/mL
Compound 4 gave a limit, no number; the forecaster's own chance of this, stated with the estimate: 25%; at least 2.0-fold (0.30 log units) between middle value and limit.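

Methoxymethyl on this aromatic carbon of the five-membered aromatic ring is the only change shown that removes the double bond outside aromatic rings, and in this assay it gave an at least 2.3-fold higher number from compound 3 to compound 4 (0.36 log units; beyond the scatter), while in place of methoxycarbonyl it gave an at least 5.8-fold higher number from compound 1 to compound 4 (0.76 log units; beyond the scatter). Compound 1 and compound 3, which both keep that double bond, give actual numbers and compound 4 does not, so this position tolerates the swap of oxygen for sulfur in the group far better than the loss of the double bond, although compound 2 goes against any simple link, as it keeps the double bond and still gives no actual number. The step between compound 2 and compound 4 cannot be read because both stand at the same limit: the limit of > 10 ug/mL in this assay, at which 2 of the 4 values shown sit.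

The compounds shown leave open how far past this limit compound 4 lies, and so the true size of its steps. They also leave open whether a carboxylic acid or an amine on this aromatic carbon would give an actual number in this assay.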